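Removing one methoxy from compound 1

A few compounds are considered here, and "the series" means these few. Any claim that something is new, unique, unknown or untested is made for them only; others in the source may bear on it.

compound 1: `COc1ccc(CNc2nc3cc(N)cc(N)c3nc2-c2ccccc2)cc1OC` — 75900 nM
compound 2: `COc1cc(CNc2nc3cc(N)cc(N)c3nc2-c2ccccc2)cc(OC)c1OC` — < 50200 nM
compound 3: `CCOC(=O)[C@H](CCC(=O)O)NC(=O)c1ccc(Oc2nc3cc(N)cc(N)c3nc2-c2ccccc2)cc1` — < 50200 nM

Among the compounds with values here, in a functional assay on 786-0 cells (Homo sapiens) for inhibition, read by sulforhodamine B assay, with a stated time of 48 h (on this read-out higher numbers stand for lower toxicity in this test and lower numbers for higher toxicity in this test), compound 1 gives 75900 nM, the only full number among the three. Compound 2 gives < 50200 nM, which is a limit of the assay. Compound 3 likewise gives < 50200 nM, a limit. Compound 4 `COc1ccc(CNc2nc3cc(N)cc(N)c3nc2-c2ccccc2)cc1` differs from compound 1 by hydrogen in place of methoxy on an aromatic carbon. Within the data shown here, the one measured step bearing on this, an at least 1.5-fold lower number from compound 1 to compound 2 (0.17 log units; that floor lies within the scatter), runs in the opposite sense, adding a methoxy, and its floor lies within the scatter (the limit of < 50200 nM in this assay, at which 2 of the 3 values shown sit). Removing a methoxy is therefore expected to move the number little, a step of a 1.1-fold higher number from compound 1 to compound 4 (0.02 log units; within the scatter). Compound 4 is estimated at 80000 nM, between 35000 nM and 180000 nM.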

Compound 4, concentration lethal to 50% of the cells: < 100000 nM
Compound 4 was reported as a limit; the forecaster's own chance of this, stated with the estimate: 25%; the middle value lies beyond the limit too.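

Within the data shown here, compound 4 stands only as a limit, so no step from compound 1 to compound 4 can be read. The compounds shown leave open how far the number moves on going from 3,4-dimethoxyphenyl to 4-methoxyphenyl.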